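A few compounds are considered here, and "the series" means these few. Any claim that something is new, unique, unknown or untested is made for them only; others in the source may bear on it.

Of the compounds shown here, two built on a shared core have so far been tested in an assay on microsomes from intestine for inhibition of acyl-CoA:cholesterol acyltransferase (Oryctolagus cuniculus); a lower number here means a stronger inhibitor, a higher number a weaker inhibitor. Compound 1 `CCCCCCCC/C=C/CCCCCCC(C)(C)C(=O)Nc1c(OC)cc(OC)cc1OC` gives 44 nM. Compound 2 `CCCCCCCCCCCCC(C)(C)C(=O)Nc1c(OC)cc(OC)cc1OC` gives 63 nM. On these numbers compound 2 stands alongside compound 1 rather than apart from it: the step of a 1.4-fold higher number from compound 1 to compound 2 (0.16 log units; within the scatter) lies within the usual scatter of repeated measurements, so the two cannot be told apart.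

Compound 3 `CCCCCCCCCCCCCCC(C)(C)C(=O)Nc1c(OC)cc(OC)cc1OC` has not yet been measured. It differs from compound 2 by ethyl in place of hydrogen on a saturated chain carbon, ten or more bonds along the chain from a carbonyl carbon. Among the measured compounds shown here, only one measured step bears on this kind of change, the exchange of one chain end for another in a 1.4-fold higher number from compound 1 to compound 2 (0.16 log units; within the scatter), and it left the number essentially where it was. On that single comparison, extending the chain a little further in compound 3 is expected to give no step beyond the scatter in this assay, in either direction. The value expected for compound 3 is 55 nM, within a range from 25 nM to 130 nM. This corresponds to an expected step of a 1.1-fold lower number from compound 2 to compound 3 (0.06 log units; within the scatter).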

Compound 3, half-maximal inhibitory concentration: 44 nM
Beside the measured number, compound 3's estimate is 1.3-fold (0.10 log units) above it; the measured number falls inside the stated range.
By their numbers in this assay, from the lowest: compounds 1, 3 and 2 (each within the scatter of the next).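

In this assay, ethyl in place of hydrogen on a saturated chain carbon, ten or more bonds along the chain from a carbonyl carbon, gives a 1.4-fold lower number from compound 2 to compound 3 (0.16 log units; within the scatter). Among the compounds shown here, until now, the only comparison was between two chain ends of different make-up, so this is the first reading of simple chain extension on its own, and at this position the extension leaves the number within the scatter. The other new comparison, the exchange of one chain end for another on a saturated chain carbon, seven bonds along the chain from a carbonyl carbon, gives no change at the digits printed from compound 1 to compound 3 (within the scatter), so these two chain ends cannot be told apart here either, and no measurement is available to explain this tolerance.

These compounds leave open how far the chain can be changed, since a much shorter chain or a much longer chain might move the number beyond the scatter. They also leave open what a hydroxyl group, an amine or a carboxylic acid at the chain end would do.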